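The compounds below may be only part of what the source reports. "The series", "measured", "known", "first", "only" and "open" are said of these compounds alone.

Compound 1, `Cc1ccc(NC(=O)N[C@H](C)c2ccccc2)cc1`, gives 100% in an ADME assay on the whole organism with Oryza sativa as the target, tested at 0.1 uM; a higher number here means a weaker effect of the compound at the concentration tested, a lower number a stronger effect. Compound 2, `CCc1ccc(NC(=O)N[C@H](C)c2ccccc2)cc1`, gives 95% in this assay, and compound 3, `CCCCCc1ccc(NC(=O)N[C@H](C)c2ccccc2)cc1`, gives 100%. Compound 1 stands level with compound 3 at the digits shown, the two together the highest of the three numbers; its nearest neighbour is compound 3, with no change at the digits printed from compound 1 to compound 3 (within the scatter), and its furthest is compound 2, with a number 5 percentage points lower from compound 1 to compound 2 (within the scatter). The remaining step, a number 5 percentage points higher from compound 2 to compound 3 (within the scatter), also lies within the scatter. All three numbers thus describe compounds with little effect at the concentration tested, and lengthening the alkyl chain on the shared core has not moved the read-out.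

Compound 4, `Cc1ccc(NC(=O)N[C@H](C)c2ccccc2)c(F)c1`, differs from compound 1 by fluoro in place of hydrogen on an aromatic carbon. Among the measured compounds shown here, none of the measured steps touches an aromatic carbon; each alters a saturated chain carbon, and each stayed within the scatter. For the measured compounds named here, no measured step therefore bears directly on this change, and nothing in the three numbers suggests that any alteration of this core has shifted the read-out. Compound 4 is therefore expected to show a number 3 percentage points lower from compound 1 to compound 4 (within the scatter), a step that should fall within the scatter. The estimate for compound 4 is 97%, with a range from 85% to 100%.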

Compound 4, a percentage reported as activity, at one concentration (the size of the read-out at that concentration, not a potency): 98%
Compound 4: the middle estimate sits 1 percentage points below what was measured; measured number inside the range.
By their numbers in this assay, from the lowest: compounds 2, 4, 1 and 3 (each within the scatter of the next).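

Among the compounds shown here, compound 4 is the only compound here changed on an aromatic carbon rather than on a saturated chain carbon, and in this assay fluoro in place of hydrogen at this position, ortho to a large group and meta to a methyl group, gives a number 2 percentage points lower from compound 1 to compound 4 (within the scatter). This single fluorine therefore extends the earlier picture from the alkyl chain to the aromatic ring: this change, like the chain changes before it, produces no step beyond the scatter, and the shared core still shows little effect at the concentration tested. The compounds shown offer no measurement that could explain why this fluoro step is so small.

A single fluorine at one position cannot show whether a chlorine atom, a methoxy group, an amine or a carboxylic acid in the same place would leave the read-out just as unmoved. From the compounds shown here alone, it also remains open whether fluoro on another aromatic carbon of this ring, or on the second aromatic ring of the shared core, would give a step beyond the scatter.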